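Trifluoromethyl in Place of Methyl: Expecting Compound 4

The compounds below may be only part of what the source reports. "The series", "measured", "known", "first", "only" and "open" are said of these compounds alone.

Measured so far in a functional assay on NCI-H1975 cells (Homo sapiens) for inhibition, read by sulforhodamine B assay, tested at 10 uM; on this read-out lower numbers stand for less inhibition and higher numbers for more inhibition at the one concentration tested (going by the name of the read-out):
compound 1 `CN1CCN(c2ccc(C3=NN(C(=O)CCCl)C(c4ccc(N(C)C)cc4)C3)cc2)CC1` gives -0.2%
compound 2 `CN1CCN(c2ccc(C3=NN(C(=O)c4ccc(F)cc4)C(c4ccc(N(C)C)cc4)C3)cc2)CC1` gives 32.2%
compound 3 `Cc1ccc(S(=O)(=O)N2N=C(c3ccc(N4CCN(C)CC4)cc3)CC2c2ccc(N(C)C)cc2)cc1` gives 38.1%

Compound 3 carries the highest of the three numbers, but its margin over compound 2 is a number 5.9 percentage points higher from compound 2 to compound 3 (within the scatter), so the two cannot be told apart. Its distance from compound 1 is a number 38.3 percentage points higher from compound 1 to compound 3 (beyond the scatter), and the step of a number 32.4 percentage points higher from compound 1 to compound 2 (beyond the scatter) is of the same kind: both large steps exchange the group on the ring nitrogen, replacing a 2-chloroethyl carbonyl by an aromatic group.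

Compound 4 `CN1CCN(c2ccc(C3=NN(S(=O)(=O)c4ccc(C(F)(F)F)cc4)C(c4ccc(N(C)C)cc4)C3)cc2)CC1` differs from compound 3 in one place: trifluoromethyl in place of methyl on an aromatic carbon. For the measured compounds named here, none of the measured steps touches this position; all three exchange the whole group on the ring nitrogen, so no step bears directly on the change. The nearest comparison is compound 2 against compound 3, where one aromatic group on that nitrogen gives way to another and the outcome is a number 5.9 percentage points higher from compound 2 to compound 3 (within the scatter), within the scatter. On that basis the step expected in this assay is a number 0.1 percentage points lower from compound 3 to compound 4 (within the scatter), nothing beyond the scatter in either direction. Compound 4 is therefore estimated at 38%, with a range from 20% to 56%.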

Compound 4, a percentage reported as inhibition, at one concentration (the size of the read-out at that concentration, not a potency): 18.9%
Beside the measured number, compound 4's estimate is 19.1 percentage points above it, and the stated range ends above it.
By their numbers in this assay, from the lowest: compound 1; then compound 4; then compounds 2 and 3 (each within the scatter of the next).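

The far end of the aromatic ring on the sulfonyl group turns out to be a position that matters: in this assay, trifluoromethyl in place of methyl on that ring gives a number 19.2 percentage points lower from compound 3 to compound 4 (beyond the scatter). The earlier steps shown here all exchanged the whole group on the ring nitrogen, and the exchange of one aromatic group for another gave only a number 5.9 percentage points higher from compound 2 to compound 3 (within the scatter), so they gave no sign that a single substituent could count for more than that larger exchange. Nothing in the data shown gives a reason for this drop.

With only methyl and trifluoromethyl compared at this position, the compounds shown leave open whether the read-out follows any trend there, and a plain hydrogen, a methoxy group or an amine on the same aromatic carbon would begin to answer that. They also leave open whether trifluoromethyl in place of the fluorine of compound 2 would lower the number in the same way when the ring is attached through a carbonyl rather than a sulfonyl group.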